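The source may hold more compounds than are shown below. What is called first, only, known or untested is meant among the compounds shown, and "the series" means these compounds.

Measured so far:
Compound 1 `Oc1cc(CCc2ccccc2)cc(O)c1O`: 106000 nM
Compound 2 `COc1cc(O)c(C(=O)O)c(CCc2ccc3ccccc3c2)c1`: 65000 nM

In an ADME assay on HEK293 cells (Homo sapiens) for cytotoxicity, read by resazurin assay, with a stated time of 24 h (on this read-out higher numbers stand for lower toxicity in this test and lower numbers for higher toxicity in this test), compound 2 gives 65000 nM, and compound 1 gives 106000 nM in this assay. The gap between the two sits within the usual scatter, so neither compound stands apart from the other. Compound 3 `Cc1cc(O)c(C(=O)O)c(CCc2ccc3ccccc3c2)c1` differs from compound 2 in one place: methyl in place of methoxy on an aromatic carbon. Among the compounds with values here, no step between two measured compounds is known here, so there is nothing to lean on for this change. The step of no change at the digits printed from compound 2 to compound 3 (within the scatter) is expected to be small, in no clear direction and within the scatter. Compound 3 is estimated to give 65000 nM, between 30000 nM and 140000 nM.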

Compound 3, half-maximal cytotoxic concentration: 40000 nM
The estimate for compound 3 lay 1.6-fold (0.21 log units) above the measured number; measured number inside the range.
By their numbers in this assay, from the lowest: compounds 3, 2 and 1 (each within the scatter of the next, the first and the last beyond it).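

Methyl in place of methoxy on this aromatic carbon, para to a carboxy group, gives a 1.6-fold lower number from compound 2 to compound 3 (0.21 log units; within the scatter) in this assay. Within the data shown here, this is the first single-place step available, and it shows that this swap, which removes one oxygen and one hydrogen-bond acceptor, leaves the number within the usual scatter. Nothing measured here gives a reason for this result.

From the compounds shown here alone, an amine, a chlorine atom or a longer chain at this position remains open. So does whether the same swap would stay within the scatter on another core.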